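The source may hold more compounds than are shown below. What is called first, only, known or untested is meant among the compounds shown, and "the series" means these compounds.

Measured so far:
compound 1, `Cc1cc(NC(=O)Nc2ccc(C(N)=O)cc2)c2ccccc2n1`: > 25000 nM
compound 2, `Cc1cc(NC(=O)Nc2ccc(OC(F)(F)F)cc2)c2ccccc2n1`: 25000 nM

In an ADME assay on BJ cells (Homo sapiens) for cytotoxicity, with a stated time of 72 h (on this read-out higher numbers stand for an effect only at larger amounts of compound and lower numbers for an effect already at smaller amounts), compound 1 gives > 25000 nM, and this is a limit of the assay rather than a number. In this assay compound 2 gives 25000 nM. The step of a number no higher from compound 1 to compound 2 (the limit leaves the size open) therefore has no readable size. Compound 2 thus stands as the only compound of the pair with an actual number, the other value being a limit, as shown by the limit of > 25000 nM in this assay, at which 1 of the 2 values shown sits.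

The next compound, compound 3, is `CCc1ccc(NC(=O)Nc2cc(C)nc3ccccc23)cc1`. It differs from compound 2 as follows: ethyl in place of trifluoromethoxy on an aromatic carbon. Within the data shown here, the only measured step, the one from compound 1 to compound 2, concerns a different pair of groups at the same place and its size could not be read, so it gives no scale for the present change. Nothing measured here points to a step in either direction beyond the scatter, and the values shown sit at the edge of what this assay reports. Compound 3 is therefore expected to lie close to compound 2, with an estimated step of no change at the digits printed from compound 2 to compound 3 (within the scatter). The estimate for compound 3 is 25000 nM, between 10000 nM and 60000 nM, with a real chance that only a limit is reported.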

Compound 3, half-maximal effective concentration in the BJ assay: > 25000 nM
Compound 3 gave a limit, no number; the forecaster's own chance of this, stated with the estimate: 55%; the middle value lies on the limit itself.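

In the BJ assay compound 3 reports only a limit, so neither step to it, from compound 1 or from compound 2, can be read, and this read-out gives no scale for a change at this place: the limit of > 25000 nM in the BJ assay, at which 2 of the 3 values shown sit. Among these compounds, what the earlier compounds did not show is a size for a change here, and that size comes from a different read-out: in a physicochemical assay for solubility, at pH 7.4 (a higher number here means a more soluble compound, a lower number a less soluble compound), compound 2 gives 300 nM, and compound 3 gives 3300 nM. Ethyl in place of trifluoromethoxy, on an aromatic carbon para to a large group, thus separates the two compounds clearly in solubility, while the cytotoxicity read-out leaves them without a readable step: the measured solubility of compound 2, 300 nM, and of compound 3, 3300 nM, an 11-fold higher number (1.04 log units; beyond the scatter).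

The compounds shown leave open whether this rise belongs to ethyl itself or would also appear with a longer chain, such as propyl, or with a methoxy group at the same place. They also leave open how an amine or a carboxylic acid at this place would stand in the physicochemical assay, and whether any such group would give a number rather than a limit in the BJ assay, where ethyl in place of trifluoromethoxy shows only a number no lower from compound 2 to compound 3 (the limit leaves the size open).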